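Aminoalkoxy chain variants on the core of compound 1

The compounds below may be only part of what the source reports. "The series", "measured", "known", "first", "only" and "open" are said of these compounds alone.

compound 1 `CCCCCOc1c(-c2cc(OC)c(OC)c(OC)c2)oc2ccccc2c1=O` — > 50000 nM
compound 2 `CCN(CC)CCCOc1c(-c2cc(OC)c(OC)c(OC)c2)oc2ccccc2c1=O` — > 50000 nM
compound 3 `CCN(CC)CCCCOc1c(-c2cc(OC)c(OC)c(OC)c2)oc2ccccc2c1=O` — 13300 nM

All three were read in a functional assay on DU-145 cells (Homo sapiens) for antiproliferative activity, read by WST assay, with a stated time of 3 days; a lower number here means a stronger inhibitor, a higher number a weaker inhibitor. Compound 1 gives only a limit of the assay, > 50000 nM, not a number. Compound 2 also gives a limit, > 50000 nM. Compound 3 gives 13300 nM. Two of the three values sit at the limit of > 50000 nM in this assay, at which 2 of the 3 values shown sit, so compound 1 stands at the ceiling of what the assay reports, with a single numbered value beneath it.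

Compound 4 `CCCN(CCC)CCCOc1c(-c2cc(OC)c(OC)c(OC)c2)oc2ccccc2c1=O` is not yet measured. Its difference from compound 1 is dipropylamino in place of ethyl on a saturated chain carbon, three bonds along the chain from an oxygen on an aromatic ring. The closest measured comparison is a step that the two limits leave unreadable from compound 1 to compound 2, where both ends are limits and no size can be read. The two readable steps, an at least 3.7-fold lower number from compound 1 to compound 3 (0.57 log units; beyond the scatter) and an at least 3.7-fold lower number from compound 2 to compound 3 (0.57 log units; beyond the scatter), both run downward and both involve the amine at the four-bond position, which compound 4 does not share. Compound 4 keeps the three-bond position of compound 2 with propyl in place of ethyl on nitrogen. A downward step an at least 1.6-fold lower number from compound 1 to compound 4 (0.22 log units; that floor lies within the scatter) is expected, though likely small and possibly unreadable. Compound 4 is estimated at 30000 nM, within 6000 nM to 90000 nM.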

Compound 4, half-maximal inhibitory concentration: > 50000 nM
Compound 4: only a limit was reported; the forecaster's own chance of this, stated with the estimate: 45%; middle value at least 1.6-fold (0.22 log units) away from the limit.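

In this assay compound 4 gives only a limit, > 50000 nM. Among these compounds, the one readable step is an at least 3.7-fold higher number from compound 3 to compound 4 (0.57 log units; beyond the scatter), so dipropylamino at this place, on a saturated chain carbon three bonds along the chain from an oxygen on an aromatic ring, does not reach the number seen with (diethylamino)methyl there. Changing ethyl to propyl on the nitrogen of the shorter chain therefore gives no readable gain, and the steps from compound 1 and from compound 2 to compound 4 cannot be read, with both ends limits: the limit of > 50000 nM in this assay, at which 3 of the 4 values shown sit.

Open, as far as these compounds go, is whether dipropylamino on the longer chain of compound 3, or a ring amine such as piperidine or morpholine on either chain, gives a readable number. From the compounds shown here alone, how compound 1, compound 2 and compound 4 rank among themselves also stays unknown.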